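The source may report more compounds than this note shows. Statements on the series, on what has been measured and on what is new or still open speak of the compounds shown alone.

Compound 3 `COc1ccc(-c2cccc(C(=O)N(C)C)c2)cc1S(=O)(=O)Nc1ccc2cccc(NC(=O)c3ccccc3)c2c1` is the only one of the three measured compounds to give a number in a functional assay on CHO cells for agonist activity at Orexin receptor type 2 (Homo sapiens) (on this read-out higher numbers stand for an effect only at larger amounts of compound and lower numbers for an effect already at smaller amounts), where compound 3 gives 873 nM. Compound 1 `COc1ccc(-c2cccc(C(=O)N(C)C)c2)cc1S(=O)(=O)Nc1ccc2ccc(NC(=O)c3ccccc3)cc2c1` reaches only the limit of the assay, > 10000 nM. Compound 2 `COc1ccc(-c2cccc(C(=O)N(C)C)c2)cc1S(=O)(=O)Nc1ccc2ccc(N(C)C(=O)c3ccccc3)cc2c1` likewise sits at the limit, > 10000 nM. Going by the values given here, the single measured step, a step that the two limits leave unreadable from compound 1 to compound 2, is therefore unreadable, since both of its compounds sit at the limit of > 10000 nM in this assay, at which 2 of the 3 values shown sit. Compound 4 `COc1cccc(C(=O)Nc2cccc3ccc(NS(=O)(=O)c4cc(-c5cccc(C(=O)N(C)C)c5)ccc4OC)cc23)c1` differs from compound 3 by methoxy in place of hydrogen on an aromatic carbon. Among the compounds with values here, none of the measured steps concerns a methoxy for hydrogen exchange, so no direction can be drawn from them, and a step within the scatter in this assay is expected, namely a 1.0-fold higher number from compound 3 to compound 4 (0.01 log units; within the scatter). Compound 4 is accordingly estimated at 900 nM, within 300 nM to 3000 nM.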

Compound 4, half-maximal effective concentration: 24.3 nM
Estimate against measurement, compound 4: 37-fold (1.57 log units) above, and the stated range ends above it.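

In this assay, the phenyl of the benzamido group proves sensitive to substitution: methoxy in place of hydrogen on an aromatic carbon, meta to a large group, gives a 36-fold lower number from compound 3 to compound 4 (1.56 log units; beyond the scatter). This is the only readable step among the compounds shown, and it shows that one change on this ring, away from the shared core, moves the number well beyond the scatter. No measured property shown here accounts for the size of this step. On these data alone, whether ethoxy, an amine or a carboxylic acid on the same carbon would act as methoxy does remains open, as does the effect of methoxy on the other carbons of this ring.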